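The source may report more compounds than this note shows. Statements on the series, on what has been measured and on what is new or still open speak of the compounds shown alone.

Three compounds share a common core in which a sulfonyl-linked phenyl ring sits on a fused two-ring system that carries a saturated amine-containing ring. Compound 1 `O=S(=O)(c1ccccc1)c1cn(C2CCNCC2)c2ccccc12` was prepared, but in a functional assay on HeLa cells for agonist activity at 5-hydroxytryptamine receptor 6 (Homo sapiens), read by cAMP accumulation and immunoassay, with a stated time of 10 min (on this read-out higher numbers stand for an effect only at larger amounts of compound and lower numbers for an effect already at smaller amounts), compound 1 stands as "not determined" (no result reported), with no result reported. Compound 2 `CCN1CCCC(n2cc(S(=O)(=O)c3ccccc3)c3ccccc32)C1` gives 31 nM in this assay. Compound 3 `O=S(=O)(c1cccc(F)c1)c1cn(C2CCCNC2)c2ccccc12` gives 56 nM in this assay, the higher of the two reported numbers, though its gap to compound 2 is within the usual scatter of repeated measurements, so the two cannot be told apart.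

Compound 4 `COc1ccc2c(c1)c(S(=O)(=O)c1cccc(F)c1)cn2C1CCCNC1` differs from compound 3 in one place: methoxy in place of hydrogen on an aromatic carbon, on the fused six-membered ring of carbon only. For the measured compounds named here, no measured pair in this set shows what such an addition does, so there is nothing to scale an expectation from. The working assumption is that the step from compound 3 to compound 4 is expected to be small, a 1.4-fold lower number from compound 3 to compound 4 (0.15 log units; within the scatter), not beyond the scatter in either direction. Compound 4 is therefore estimated at 40 nM, with a plausible range from 10 nM to 160 nM.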

Compound 4, half-maximal effective concentration: 73 nM
The estimate for compound 4 lay 1.8-fold (0.26 log units) below the measured number; measured number inside the range.
By their numbers in this assay, from the lowest: compounds 2, 3 and 4 (each within the scatter of the next, the first and the last beyond it).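

The earlier compounds shown here offered no measured pair for a change on the fused six-membered ring of carbon only, and this step supplies the first. In this assay, methoxy in place of hydrogen on this aromatic carbon gives a 1.3-fold higher number from compound 3 to compound 4 (0.12 log units; within the scatter), so the two compounds cannot be told apart, and within this pair the position takes a group of 2 heavy atoms without a change that this read-out can resolve. No measurement shown offers an explanation for the size of this step.

From the compounds shown here alone, whether the same position would respond in the same way to an amine, a carboxylic acid or a longer chain such as butoxy remains open. Going by these compounds, it is also open whether methoxy would give a similar result on the other aromatic carbons of this ring.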